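Benzyl for isopropyl on the ether oxygen of compound 2

The compounds below may be only part of what the source reports. "The series", "measured", "known", "first", "only" and "open" are said of these compounds alone.

Going by the values given here, compound 2 `CCc1oc2c(C)c(OC(C)C)ccc2c(=O)c1Br` is the only compound with a number in a functional assay on KB cells (Homo sapiens) for antiproliferative activity, read by sulforhodamine B assay, with a stated time of 72 h (on this read-out lower numbers stand for stronger inhibition of growth and higher numbers for weaker inhibition of growth), where compound 2 gives 22600 nM. Compound 1 `CCc1cc(=O)c2ccc(OCc3ccccc3)c(C)c2o1` reaches only a limit, > 33900 nM, and this limit is noted as the limit of > 33900 nM in this assay, at which 1 of the 2 values shown sits. Compound 3 `CCc1oc2c(C)c(OCc3ccccc3)ccc2c(=O)c1Br` differs from compound 2 by benzyl in place of isopropyl on an oxygen on an aromatic ring. Among the compounds with values here, no step between measured compounds is at hand, so only a small change is expected, roughly within the scatter and leaning toward weaker inhibition, as a 1.2-fold higher number from compound 2 to compound 3 (0.06 log units; within the scatter) indicates. Compound 3 is therefore estimated at 26000 nM in this assay, within 8000 nM to 60000 nM.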

Compound 3, concentration for 50% growth inhibition: > 26700 nM
Compound 3: a limit, no number (the forecaster's own chance of this, stated with the estimate: 35%); middle value at least 1.0-fold (0.01 log units) away from the limit.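

In this assay compound 3 gives only a limit, > 26700 nM, so this change on the oxygen has no exact size. Going by these compounds, the step is an at least 1.1-fold higher number from compound 2 to compound 3 (0.07 log units; that floor lies within the scatter), so benzyl in place of isopropyl brings no gain in growth inhibition here, while the true size of any loss stays unknown. The step for bromo in place of hydrogen on an aromatic carbon cannot be read, as both of its values are limits. The compounds shown leave open whether an amine or a carboxylic acid on this oxygen would give stronger inhibition of growth.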